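Swapping the Aryl Group on a Shared Piperazine Oxime Core

A few compounds are considered here, and "the series" means these few. Any claim that something is new, unique, unknown or untested is made for them only; others in the source may bear on it.

Of the compounds shown here, three built on one core have been tested in a functional assay on HEK293 cells with D(4) dopamine receptor (Homo sapiens) as the target, read by FLIPR; on this read-out lower numbers stand for smaller maximal responses and higher numbers for larger maximal responses. Compound 1 `O/N=C(/CCN1CCN(c2ccccn2)CC1)c1ccccc1` gives 74%, compound 2 `Cc1cccc(/C(CCN2CCN(c3ccccn3)CC2)=N/O)c1` gives 74%, and compound 3 `CCO/N=C(\CCN1CCN(c2ccccc2C#N)CC1)c1ccccc1` gives 82%. The values for compound 1 and compound 2 lie within the usual scatter of that for compound 3, so no ranking among the three is secure. Compound 4 `CCO/N=C(\CCN1CCN(c2cccc(OCC)c2)CC1)c1ccccc1` has not yet been measured. It differs from compound 3 in one place: 3-ethoxyphenyl in place of 2-cyanophenyl on an amine nitrogen in a ring. For the measured compounds named here, no measured pair shows an exchange of this kind, so there is no step to lean on, and the three known values sit close together. The expected step from compound 3 in this assay is a number 4 percentage points lower from compound 3 to compound 4 (within the scatter), none beyond the scatter. Compound 4 is therefore estimated at 78%, within a range of 62% to 94%.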

Compound 4, largest response reached (reported as efficacy), in percent of the reference or control that the assay uses: 84%
Beside the measured number, compound 4's estimate is 6 percentage points below it; measured number inside the range.
By their numbers in this assay, from the lowest: compounds 1, 2, 3 and 4 (each within the scatter of the next).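

In this assay, exchanging 2-cyanophenyl for 3-ethoxyphenyl on the amine nitrogen in the ring gives a number 2 percentage points higher from compound 3 to compound 4 (within the scatter), so this position accepts both substituted phenyl groups with the maximal response the same within the scatter. Nothing available explains this result. The two groups differ in both the substituent and its place on the phenyl ring, and the compounds shown do not separate these two changes. Going by these compounds, whether an amine or a carboxylic acid on that ring, or a longer chain in place of ethoxy, would keep the response also stays open.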